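A trimethoxyphenyl swap on compound 1

The source may report more compounds than this note shows. Statements on the series, on what has been measured and on what is new or still open speak of the compounds shown alone.

Three related compounds have been measured so far in a functional assay on A549 cells (Homo sapiens) for inhibition, read by sulforhodamine B assay, with a stated time of 48 h, tested at 50 uM (on this read-out higher numbers stand for more inhibition of growth at the one concentration tested and lower numbers for less inhibition of growth), and they span a clear range. Compound 1 (`COc1ccc([C@@H]2C/C(=N/OCc3cn(-c4ccc(O)cc4)nn3)c3cc(CC=C(C)C)c(OC)cc3O2)cc1`) gives 52% and is the lowest of the three. Compound 2 (`COc1ccc([C@@H]2C/C(=N/O)c3cc(CC=C(C)C)c(OC)cc3O2)cc1`) reads 66% and stands above compound 1 by more than the scatter. Compound 3 (`COc1cc2c(cc1CC=C(C)C)/C(=N/O)C[C@@H](c1ccc(O)cc1)O2`) reads 80% and is the furthest from compound 1, also beyond the scatter.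

Compound 1 is the only one of these three that carries a five-membered aromatic ring with 3 nitrogen. Compound 4 (`COc1ccc([C@@H]2C/C(=N/OCc3cn(-c4cc(OC)c(OC)c(OC)c4)nn3)c3cc(CC=C(C)C)c(OC)cc3O2)cc1`) keeps that ring. The change is 3,4,5-trimethoxyphenyl in place of 4-hydroxyphenyl on an aromatic nitrogen of that ring (3,4,5-trimethoxyphenyl in place of 4-hydroxyphenyl on an aromatic nitrogen) and the rest of the structure stays the same.

Going by the values given here, no measured pair shows what such a swap does, so the data offer no direction for it. The expectation therefore rests on compound 1 at 52% as its only close reference. No step beyond the scatter is expected in this assay and the estimated a number 2 percentage points lower from compound 1 to compound 4 (within the scatter) is correspondingly small. Compound 4 is estimated at 50% with an expected range from 32% to 68% in this measurement.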

Compound 4, percent growth inhibition at one concentration: 28%
Estimate against measurement, compound 4: 22 percentage points above, and the stated range ends above it.
By their numbers in this assay, from the lowest: compound 4; then compound 1; then compound 2; then compound 3.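

Going by these compounds alone, the group on the aromatic nitrogen of the five-membered aromatic ring with 3 nitrogen proves not to be a silent position in this assay where 3,4,5-trimethoxyphenyl in place of 4-hydroxyphenyl gives a number 24 percentage points lower from compound 1 to compound 4 (beyond the scatter) and so provides the first comparison here between two compounds that differ in one place. This single step bundles several changes, as the hydrogen-bond donor of 4-hydroxyphenyl goes while the heavy atoms and hydrogen-bond acceptors of the entering group increase, and it cannot assign the drop to any one of them. Nothing available bears on why the number falls.

As far as these compounds go, whether the drop follows from losing the hydroxyl group or from adding the three methoxy groups remains open, and a plain phenyl or a 4-methoxyphenyl on the same nitrogen would help separate the two. From the compounds shown here alone, how an amine or a carboxylic acid on that phenyl ring would read is equally open, as is whether a step of this size would hold on the growth of other cell lines.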